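A few compounds are considered here, and "the series" means these few. Any claim that something is new, unique, unknown or untested is made for them only; others in the source may bear on it.

Within the data shown here, in a functional assay on A549 cells (Homo sapiens) for antiproliferative activity, read by sulforhodamine B assay, with a stated time of 48 h (a lower number here means a stronger inhibitor of growth, a higher number a weaker inhibitor of growth), compound 2 `CCCNc1nc(Nc2ccc(OC)cc2)nc2ccccc12` gives 3530 nM, the lowest number so far. Compound 1 `COc1ccc(Nc2nc(NCCCO)c3ccccc3n2)cc1` gives 15200 nM, and compound 3 `CNc1nc(Nc2ccc(OC)cc2)nc2ccccc12` gives 16100 nM. Compound 4 `COc1ccc(Nc2nc(NC3CC3)c3ccccc3n2)cc1` keeps the shared core and has cyclopropyl in place of propyl on a nitrogen on an aromatic ring. Among the measured compounds shown here, two measured steps touch this same group. With hydrogen in place of hydroxy, the number moved by a 4.3-fold lower number from compound 1 to compound 2 (0.63 log units; beyond the scatter). With hydrogen in place of ethyl, it moved by a 4.6-fold higher number from compound 2 to compound 3 (0.66 log units; beyond the scatter). Both steps are modest, and neither makes a ring, so the evidence is indirect. A small rise, perhaps within the scatter, is expected, with an estimated 1.7-fold higher number from compound 2 to compound 4 (0.23 log units; within the scatter). For compound 4 the estimate is 6000 nM, with an expected range of 2500 nM to 15000 nM.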

Compound 4, concentration for 50% growth inhibition: 13000 nM
For compound 4 the middle estimate is 2.2-fold (0.34 log units) below the measured one; measured number inside the range.
By their numbers in this assay, from the lowest: compound 2; then compounds 4, 1 and 3 (each within the scatter of the next).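

With the same count of three carbons on the nitrogen, propyl and cyclopropyl do not behave alike: closing the chain into a ring gives a 3.7-fold higher number from compound 2 to compound 4 (0.57 log units; beyond the scatter), so the carbon count alone does not set the result at this position. Cyclopropyl instead sits level with methyl, with a 1.2-fold lower number from compound 3 to compound 4 (0.09 log units; within the scatter), and with 3-hydroxypropyl, with a 1.2-fold lower number from compound 1 to compound 4 (0.07 log units; within the scatter), leaving propyl alone at the low end of these four. Nothing measured here accounts for this difference. As far as these compounds go, whether a longer chain such as butyl, or a branched one such as isopropyl, would match propyl remains open.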